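From compound 3 to compound 4: an expected clearance

The source may hold more compounds than are shown below. What is called first, only, known or untested is meant among the compounds shown, and "the series" means these compounds.

Compound 1 `Cc1ccc2[nH]c(C(=O)N[C@H]3CN(S(=O)(=O)c4ccccc4)C[C@@H]3C(=O)N[C@@H]3CCCN(C)C3)cc2c1`: 50 mL.min-1.g-1
Compound 2 `O=C(N[C@H]1CN(S(=O)(=O)c2ccccc2)C[C@@H]1C(=O)N[C@H]1CCCNC1)c1nnc(-c2ccc(F)cc2)s1`: 8.8 mL.min-1.g-1
Compound 3 `O=C(N[C@H]1CN(S(=O)(=O)c2ccccc2)C[C@@H]1C(=O)N1C[C@H]2CCNC[C@H]21)c1cc(-c2ccccc2Cl)on1`: 7.3 mL.min-1.g-1

All three values come from an ADME assay on microsomes from liver (Homo sapiens) for metabolic stability; on this read-out lower numbers stand for slow clearance and higher numbers for fast clearance. Compound 3, at 7.3 mL.min-1.g-1, sits within the scatter of compound 2 at 8.8 mL.min-1.g-1, so the two cannot be told apart. Compound 1, at 50 mL.min-1.g-1, stands beyond the scatter from compound 3, on the fast-clearing side.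

Compound 4 `CC(=O)N1CCC[C@H](NC(=O)[C@H]2CN(S(=O)(=O)c3ccccc3)C[C@@H]2NC(=O)c2cc(-c3ccccc3Cl)on2)C1` differs from compound 3 in one place: a group of 10 heavy atoms (7 carbon, 2 nitrogen, 1 oxygen; one six-membered non-aromatic ring with 1 hetero atom) in place of a group of 8 heavy atoms (6 carbon, 2 nitrogen; one four-membered non-aromatic ring with 1 hetero atom, one six-membered non-aromatic ring with 1 hetero atom), on a carbonyl carbon. For the measured compounds named here, no two measured compounds differ in only one place, so the data give no direct measure of such a change. The new group also carries a substituent on its ring nitrogen. Among the measured compounds, only compound 1, at 50 mL.min-1.g-1, has a substituted ring nitrogen, though it differs elsewhere too. A moderate rise is therefore expected, with a return to the level of compound 3 still possible. The expected change is a 2.5-fold higher number from compound 3 to compound 4 (0.39 log units; beyond the scatter). Compound 4 is estimated at 18 mL.min-1.g-1, with an expected range from 7 mL.min-1.g-1 to 45 mL.min-1.g-1.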

Compound 4, intrinsic clearance in microsomes: > 300 mL.min-1.g-1
Compound 4 ended at the assay's limit (the forecaster's own chance of this, stated with the estimate: 2%); at least 16-fold (1.22 log units) between middle value and limit.
By their numbers in this assay, from the lowest: compounds 3 and 2 (each within the scatter of the next); then compound 1. At a limit, above all of these: compound 4.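

For the compounds shown here, the group on the carbonyl carbon gives the first direct reading of a change at this place: in this assay, exchanging the group with the four-membered and six-membered rings for the larger group with one six-membered ring gives an at least 41-fold higher number from compound 3 to compound 4 (1.61 log units; beyond the scatter). Going by these compounds alone, with the rest of the structure held constant, this place is clearly not indifferent to the group it carries, which the earlier compounds, none differing from another in only one place, could not show. Compound 4 gives no exact number, only a limit of the assay: the limit of > 300 mL.min-1.g-1 in this assay, at which 1 of the 4 values shown sits.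

The step alters the ring system and adds a substituent on the ring nitrogen together, so the compounds shown cannot separate the two changes. They also leave open how this place would respond to a morpholine ring or an open-chain primary amine.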